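The source may report more compounds than this note shows. Statements on the series, on what has been measured and on what is new or still open speak of the compounds shown alone.

In a functional assay on HT-29 cells (Homo sapiens) for antiproliferative activity, read by sulforhodamine B assay, with a stated time of 72 h (on this read-out lower numbers stand for stronger inhibition and higher numbers for weaker inhibition), compound 1 (`CCCCCCCOc1ccc(CCC(CO)(CO)NC(=O)CCCCCCC)c2ccccc12`) reads 18800 nM and compound 2 (`CCCCCCCOc1ccc(CCC(CO)(CO)NC(=O)OC(C)(C)C)c2ccccc12`) reads 21400 nM and so stands level with it within the scatter. Compound 3 (`C/C=C/C(=O)NC(CO)(CO)CCc1ccc(OCCCCCCC)c2ccccc12`) is not yet measured, and it carries prop-1-en-1-yl in place of tert-butoxy on a carbonyl carbon. Going by the values given here, the only measured swap at this place, tert-butoxy in place of heptyl, gave a 1.1-fold higher number from compound 1 to compound 2 (0.06 log units; within the scatter) and so stays within the scatter. That single step is thin evidence, yet it suggests no step beyond the scatter in this assay and favours no direction. The estimate therefore expects a 1.1-fold lower number from compound 2 to compound 3 (0.03 log units; within the scatter) and nothing larger. Compound 3 is estimated at 20000 nM with a range from 9000 nM to 40000 nM as the expected span.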

Compound 3, half-maximal inhibitory concentration: 36400 nM
Estimate against measurement, compound 3: 1.8-fold (0.26 log units) below, within the range that was stated.
By their numbers in this assay, from the lowest: compounds 1, 2 and 3 (each within the scatter of the next).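

In this assay the step of a 1.7-fold higher number from compound 2 to compound 3 (0.23 log units; within the scatter) and the step of a 1.9-fold higher number from compound 1 to compound 3 (0.29 log units; within the scatter) both stay within the scatter, so prop-1-en-1-yl reads level with tert-butoxy and with heptyl on this carbonyl carbon. The position therefore accepts a group of only three heavy atoms with a double bond, which the first pair alone did not show. Nothing available explains why these groups read alike. Still open, from the compounds shown here alone, is whether the position stays this flat with a phenyl ring or a chain ending in an amine, and whether any group there moves the number beyond the scatter.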